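Dichlorinated Benzyl Group on a Cytotoxicity-Silent Series

The compounds below may be only part of what the source reports. "The series", "measured", "known", "first", "only" and "open" are said of these compounds alone.

Of the compounds shown here, three with a shared core have been tested. In an ADME assay on HepG2 cells (Homo sapiens) for cytotoxicity, with a stated time of 48 h (on this read-out higher numbers stand for weaker inhibition and lower numbers for stronger inhibition), compound 1 `O=[N+]([O-])c1cc(CSc2nnc(-c3ccc(Br)cc3)n2Cc2ccccc2)cc([N+](=O)[O-])c1` gives > 30000 nM, which is a limit of the assay rather than a number. Compound 2 `CCn1c(SCc2ccccc2)nnc1-c1cc([N+](=O)[O-])cc([N+](=O)[O-])c1` likewise gives > 30000 nM, again a limit. Compound 3 `O=[N+]([O-])c1cc(-c2nnc(SCc3ccccc3)n2Cc2ccccc2)cc([N+](=O)[O-])c1` stands at > 30000 nM, also a limit. The step that the two limits leave unreadable from compound 2 to compound 3 therefore cannot be read from these limits. Compound 4 `O=[N+]([O-])c1cc(-c2nnc(SCc3ccc(Cl)c(Cl)c3)n2Cc2ccccc2)cc([N+](=O)[O-])c1` differs from compound 3 by 3,4-dichlorophenyl in place of phenyl on a saturated chain carbon bound to a sulfur. Going by the values given here, no measured step bears directly on this change; the only evidence is the limit of > 30000 nM in this assay, at which 3 of the 3 values shown sit, so the expected step that the limit leaves unreadable from compound 3 to compound 4 is none beyond the scatter. Compound 4 is thus expected to give 40000 nM, most likely reported again as a limit, within 15000 nM to 100000 nM.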

Compound 4, half-maximal inhibitory concentration: > 30000 nM
Compound 4: no number, only a limit; the forecaster's own chance of this, stated with the estimate: 80%; the middle value is on the limit's open side.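

No step can be read from compound 3 to compound 4, since each gives only a limit rather than a number: the limit of > 30000 nM in this assay, at which 4 of the 4 values shown sit.

The compounds shown leave open whether 3,4-dichlorophenyl in place of phenyl changes the result at all in this assay.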